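This account rests on a few compounds, and the source may have more. Where it says the series, first, only, none or still open, it means among the compounds named here.

Compound 1 `C[C@H](NC(=O)c1cc(Cl)ccc1OCCN)C(=O)Nc1ccc([N+](=O)[O-])cc1Cl`: > 10000 nM, a limit
Compound 2 `CC(C)C[C@H](NC(=O)c1cc(Cl)ccc1OCCN)C(=O)Nc1ccc([N+](=O)[O-])cc1Cl`: > 10000 nM, a limit
Compound 3 `CC(C)(C)OC(=O)CC[C@H](NC(=O)c1cc(Cl)ccc1OCCNC(=O)OC(C)(C)C)C(=O)Nc1ccc([N+](=O)[O-])cc1Cl`: > 10000 nM, a limit

In a functional assay on MDA-MB-231 cells (Homo sapiens) for inhibition, read by MTT assay, with a stated time of 72 h (a lower number here means a stronger inhibitor, a higher number a weaker inhibitor), compound 3 stands at > 10000 nM, which is a limit and not a number. Compound 4 `CC(C)(C)OC(=O)CC[C@H](NC(=O)c1cc(Cl)ccc1OCCN)C(=O)Nc1ccc([N+](=O)[O-])cc1Cl` differs from it by hydrogen in place of tert-butoxycarbonyl on an amine nitrogen. Within the data shown here, the only measured step is a step that the two limits leave unreadable from compound 1 to compound 2; it lies at another place and offers no size to carry over. Compound 1 and compound 2 already hold the 2-aminoethyl group, and both stay at the limit of > 10000 nM in this assay, at which 3 of the 3 values shown sit. The expected change is therefore small, an at least 1.4-fold lower number from compound 3 to compound 4 (0.15 log units; that floor lies within the scatter), and any movement should be towards stronger inhibition in this assay. Compound 4 is estimated at 7000 nM, with an expected range from 2500 nM to 15000 nM.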

Compound 4, half-maximal inhibitory concentration: 5990 nM
For compound 4 the middle estimate is 1.2-fold (0.07 log units) above the measured one; low and high end bracket the measured number.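

In this assay compound 4 gives 5990 nM, a real number rather than a limit, so this series can register in the assay. Taking tert-butoxycarbonyl off the amine nitrogen gives an at least 1.6-fold lower number from compound 3 to compound 4 (0.22 log units; that floor lies within the scatter), while on the saturated chain carbon, (tert-butoxycarbonyl)methyl gives an at least 1.6-fold lower number from compound 2 to compound 4 (0.22 log units; that floor lies within the scatter) against isopropyl and an at least 1.6-fold lower number from compound 1 to compound 4 (0.22 log units; that floor lies within the scatter) against hydrogen. All three steps are floors, and their true sizes cannot be read: the limit of > 10000 nM in this assay, at which 3 of the 4 values shown sit.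

Going by these compounds, what stays open is how a carboxylic acid in place of the tert-butyl ester would read, and whether a longer chain carrying that ester would shift the number.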